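The source may hold more compounds than are shown below. What is called first, only, known or untested is meant among the compounds shown, and "the series" means these compounds.

Measured in an ADME assay on Raji cells (Homo sapiens) for cytotoxicity, with a stated time of 72 h; a lower number here means that less compound is needed, a higher number that more compound is needed for the effect:
- compound 1 `Cc1cc(NC(=O)Nc2ccc(C(C)(C)C)cc2)c2ccccc2n1`: > 25000 nM
- compound 2 `CSc1ccc(NC(=O)Nc2cc(C)nc3ccccc23)cc1`: > 25000 nM
- compound 3 `Cc1cc(NC(=O)Nc2ccc(C(=O)O)cc2)c2ccccc2n1`: > 25000 nM

Each of these entries is a limit of the assay and not a number. Compound 3 gives only a limit, > 25000 nM. It therefore has no exact place among the three compounds, and the whole set is described by the limit of > 25000 nM in this assay, at which 3 of the 3 values shown sit.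

Compound 4 `Cc1cc(NC(=O)Nc2ccc(Cl)cc2)c2ccccc2n1` differs from compound 3 in one place, with chloro in place of carboxy on an aromatic carbon, para to a large group (chloro in place of carboxy on an aromatic carbon). Among the measured compounds shown here, three measured steps bear on this change, since each swaps the group on an aromatic carbon: a step that the two limits leave unreadable from compound 1 to compound 2, a step that the two limits leave unreadable from compound 1 to compound 3 and a step that the two limits leave unreadable from compound 2 to compound 3. None of them has a readable size, so they show only that tert-butyl, methylsulfanyl and carboxy all leave these compounds at the limit. Chloro has not yet been seen in this assay. With that evidence, no step beyond the scatter is expected, and compound 4 may again be reported only as a limit. The expected change is a number no higher from compound 3 to compound 4 (the limit leaves the size open). Compound 4 is estimated at 25000 nM. The expected range for compound 4 runs from 10000 nM to 40000 nM.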

Compound 4, half-maximal effective concentration: > 25000 nM
Compound 4 was reported as a limit; the forecaster's own chance of this, stated with the estimate: 80%; the middle value lies on the limit itself.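

In this assay compound 4 gives > 25000 nM, which is a limit of the assay and not a number. Among the compounds shown here, no step from compound 1, compound 2 or compound 3 to compound 4 can be read, and all four compounds share one description: the limit of > 25000 nM in this assay, at which 4 of the 4 values shown sit. The compounds shown leave open how far any of them lies past this limit and whether any group at this place would give a measurable value.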